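The source may report more compounds than this note shows. Statements on the series, on what has been measured and on what is new or still open speak of the compounds shown alone.

Series notes. Compound 1 `O=S(=O)(c1ccc(F)c(F)c1)c1cnc2c(F)cccc2c1-c1ccc(F)cc1` and compound 2 `N#Cc1cccc(S(=O)(=O)c2cnc3c(F)cccc3c2-c2ccc(Cl)cc2)c1` share one core and differ in both aryl groups, at the sulfonyl and on the pendant ring. In an ADME assay on microsomes from liver (Homo sapiens) for metabolic stability, tested at 2.5 uM (a higher number here means faster removal of the compound, a lower number slower removal), compound 1 gives 0.78 mL/min. In this assay compound 2 gives 0.08 mL/min, the lower of the two numbers, and the gap to compound 1 lies beyond the scatter. Compound 3 `N#Cc1cccc(S(=O)(=O)c2cnc3c(F)cccc3c2-c2ccc(F)cc2)c1` has not yet been measured in this assay. Relative to compound 2 it carries one change (fluoro in place of chloro on an aromatic carbon). Among the measured compounds shown here, no measured pair isolates this change, since compound 1 differs from compound 2 at the sulfonyl aryl group as well, so the size of this step is unknown from the data. The expected step is a 1.5-fold higher number from compound 2 to compound 3 (0.18 log units; within the scatter), of a size that stays within the scatter, with a slight lean toward a higher number. Compound 3 is therefore estimated to give 0.12 mL/min in this assay, within a range of 0.05 mL/min to 0.3 mL/min.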

Compound 3, intrinsic clearance in a liver preparation (reported as CLH), per the amount of preparation that the assay uses: 0.19 mL/min
Estimate against measurement, compound 3: 1.6-fold (0.20 log units) below; measured number inside the range.
By their numbers in this assay, from the lowest: compound 2; then compound 3; then compound 1.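

With the 3-cyanophenyl on the sulfonyl sulfur held fixed, going from 4-chlorophenyl to 4-fluorophenyl on the shared core gives a 2.4-fold higher number from compound 2 to compound 3 (0.38 log units; beyond the scatter) in this assay, so this exchange of one halogen for another moves the read-out beyond the scatter by itself. With the 4-fluorophenyl held fixed, 3-cyanophenyl in place of 3,4-difluorophenyl on the sulfonyl sulfur gives a 4.1-fold lower number from compound 1 to compound 3 (0.61 log units; beyond the scatter), which separates the sulfonyl aryl group from the pendant ring as a site of change. Nothing in hand bears on the reason for either step.

The compounds shown leave open whether the halogen step carries over when 3,4-difluorophenyl sits on the sulfonyl sulfur. They also leave open how the read-out responds to a non-halogen group on the pendant ring, such as methoxy or an amine, or to a carboxylic acid on the sulfonyl aryl group.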